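Methyl removal on an aryl amide: a cytotoxicity comparison

The compounds below may be only part of what the source reports. "The series", "measured", "known", "first", "only" and "open" are said of these compounds alone.

Measured so far:
compound 1 `Cc1ccccc1NC(=O)CSc1nncnc1-c1cccc2ccccc12` 158000 nM
compound 2 `O=C(CSc1nncnc1-c1cccc2ccccc12)Nc1ccccc1` 154000 nM
compound 3 `Cc1ccc(NC(=O)CSc2nncnc2-c2ccccc2Cl)c([N+](=O)[O-])c1` 158000 nM

All three were tested in an ADME assay on MT4 cells (Homo sapiens) for cytotoxicity, read by MTT assay; a lower number here means that less compound is tolerated, a higher number that more compound is tolerated. Compound 1 and compound 2 differ by hydrogen in place of methyl on an aromatic carbon, and this gave a 1.0-fold lower number from compound 1 to compound 2 (0.01 log units; within the scatter). Compound 3 carries a different core; the difference between the two cores is not broken down here, and its value in this assay sits level with compound 1 at the digits reported, with compound 2 within the scatter of both.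

Compound 4 `O=C(CSc1nncnc1-c1ccccc1Cl)Nc1ccccc1[N+](=O)[O-]` is not yet measured. It differs from compound 3 by hydrogen in place of methyl on an aromatic carbon, the same kind of change as between compound 1 and compound 2, though here the place is meta to a nitro group and para to a large group rather than ortho to a large group. Because a 1.0-fold lower number from compound 1 to compound 2 (0.01 log units; within the scatter) lay within the scatter, the step from compound 3 to compound 4 is expected to be about a 1.0-fold lower number from compound 3 to compound 4 (0.01 log units; within the scatter), and compound 4 is estimated at 155000 nM, with a range from 80000 nM to 300000 nM.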

Compound 4, half-maximal cytotoxic concentration: 63000 nM
Compound 4: the middle estimate sits 2.5-fold (0.39 log units) above what was measured, outside the stated range (below it).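

In this assay hydrogen in place of methyl on an aromatic carbon gave a 2.5-fold lower number from compound 3 to compound 4 (0.40 log units; beyond the scatter) on this second core. Among the compounds shown here, only this newer step stands clear of the scatter on its own, yet it cannot be told apart from the earlier step: the same change on two cores in this assay, a 1.0-fold lower number (0.01 log units; within the scatter) from compound 1 to compound 2 and a 2.5-fold lower number (0.40 log units; beyond the scatter) from compound 3 to compound 4, 2.4-fold (0.39 log units) apart, within the scatter of two such steps. The change is therefore not shown to behave differently on the two cores, but two pairs are too few to show that it carries over reliably, and neither pair explains the shift.

The compounds shown leave open what an ethyl group, a methoxy group or an amine at this place would do. They also leave open whether the same change would give a similar step on any further core.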